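The source may hold more compounds than are shown below. What is called first, only, known or untested is meant among the compounds shown, and "the series" means these compounds.

Compound 1 `Cc1cc(S(=O)(=O)/N=C(\N)N/N=C/C#Cc2ccccc2)c(SCc2ccccc2)cc1Cl`: 5000 nM in a functional assay on HeLa cells (Homo sapiens) for antiproliferative activity, read by MTT assay, with a stated time of 72 h; a higher number here means a weaker inhibitor, a lower number a stronger inhibitor
Compound 2 `Cc1cc(S(=O)(=O)/N=C(\N)N/N=C/C#Cc2ccccc2)c(SCc2ccccc2C(F)(F)F)cc1Cl`: 16000 nM in this assay

Among these two, compound 2 gives the higher number in this assay, and its only neighbour is compound 1, from which it differs by one group: a 3.2-fold higher number from compound 1 to compound 2 (0.51 log units; beyond the scatter). Compound 3 `Cc1cc(S(=O)(=O)/N=C(\N)N/N=C/C#Cc2ccccc2)c(SCc2ccc(C(F)(F)F)cc2)cc1Cl` keeps every atom of compound 2 and shifts one group: 4-(trifluoromethyl)phenyl in place of 2-(trifluoromethyl)phenyl on a saturated chain carbon bound to a sulfur. Among the measured compounds shown here, no measured pair shows this kind of shift; the one measured step shows only that adding a trifluoromethyl to the benzyl ring weakened compound 2 relative to compound 1. Whether moving that group lands nearer compound 1 or stays near compound 2 cannot be read from the data, so the expected step for compound 3 is small and uncertain: a 1.6-fold lower number from compound 2 to compound 3 (0.20 log units; within the scatter). Compound 3 is estimated at 10000 nM in this assay, with a range from 3000 nM to 40000 nM.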

Compound 3, half-maximal inhibitory concentration: 93000 nM
The estimate for compound 3 lay 9.3-fold (0.97 log units) below the measured number; measured number above the stated range.
By their numbers in this assay, from the lowest: compound 1; then compound 2; then compound 3.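

Moving the group around the ring is not a neutral change in this assay: going from 2-(trifluoromethyl)benzyl to 4-(trifluoromethyl)benzyl gives a 5.8-fold higher number from compound 2 to compound 3 (0.76 log units; beyond the scatter), so where the trifluoromethyl sits matters, not only whether it is present. Set against the plain benzyl group, the trifluoromethyl in its new place costs far more, with a 19-fold higher number from compound 1 to compound 3 (1.27 log units; beyond the scatter), a large step where the earlier addition was modest. Nothing measured here explains why the two placements differ.

Going by these compounds, both trifluoromethyl compounds give higher numbers than compound 1, so it remains open whether any group on this benzyl ring can be tolerated. A benzyl ring carrying a methoxy group or an amine instead, or a longer chain between the sulfur and the ring, could show whether a number lower than that of compound 1 is within reach.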